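From 2-bromophenyl to 3-cyanophenyl on a shared core

The compounds below may be only part of what the source reports. "The series", "measured", "known", "first", "only" and "open" are said of these compounds alone.

compound 1 `COc1cc2oc(-c3cccc(NC(=O)c4cccc(Br)c4)c3)cc(=O)c2c(OC)c1OC`: 6340 nM
compound 2 `COc1cc2oc(-c3cccc(NC(=O)c4ccccc4Br)c3)cc(=O)c2c(OC)c1OC`: 55000 nM
compound 3 `COc1cc2oc(-c3cccc(NC(=O)c4ccc([N+](=O)[O-])cc4)c3)cc(=O)c2c(OC)c1OC`: 20100 nM
compound 4 `COc1cc2oc(-c3cccc(NC(=O)c4cccc(C#N)c4)c3)cc(=O)c2c(OC)c1OC`: not yet measured

These values come from a functional assay on MCF7 cells (Homo sapiens) for inhibition, read by MTT assay; on this read-out higher numbers stand for weaker inhibition of growth and lower numbers for stronger inhibition of growth. Compound 2 stands highest of the three, at 55000 nM. The change that leads to compound 4 is 3-cyanophenyl in place of 2-bromophenyl on a carbonyl carbon. The closest measured substituent is 3-bromophenyl, and leaving it gave an 8.7-fold higher number from compound 1 to compound 2 (0.94 log units; beyond the scatter). Replacing 2-bromophenyl with 4-nitrophenyl gave a 2.7-fold lower number from compound 2 to compound 3 (0.44 log units; beyond the scatter), while the remaining measured step was a 3.2-fold higher number from compound 1 to compound 3 (0.50 log units; beyond the scatter). A modest move to a lower number is therefore expected, namely a 5.5-fold lower number from compound 2 to compound 4 (0.74 log units; beyond the scatter). The estimated value for compound 4 is 10000 nM, with an expected range of 3500 nM to 30000 nM.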

Compound 4, concentration for 50% growth inhibition: 41700 nM
The estimate for compound 4 lay 4.2-fold (0.62 log units) below the measured number; measured number above the stated range.
By their numbers in this assay, from the lowest: compound 1; then compound 3; then compounds 4 and 2 (each within the scatter of the next).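

In this assay, cyano in place of bromo gave a 6.6-fold higher number from compound 1 to compound 4 (0.82 log units; beyond the scatter), so keeping the substituent at the same ring position did not keep the low number of compound 1. The change from 2-bromophenyl gave a 1.3-fold lower number from compound 2 to compound 4 (0.12 log units; within the scatter), which leaves compound 4 level with compound 2. The change from 4-nitrophenyl gave a 2.1-fold higher number from compound 3 to compound 4 (0.32 log units; beyond the scatter), and compound 1 keeps the lowest number of the four.

No evidence here accounts for the gap between bromo and cyano. On these data alone, whether an amine or a carboxylic acid at this ring position would match bromo remains open.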